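The source may report more compounds than this note shows. Statements on the series, on what has been measured and on what is new or still open speak of the compounds shown alone.

Compound 2 `Cn1nc2c(=O)n(CC3(O)CCN(Cc4ccc(-c5ccco5)cc4Cl)CC3)cnc2c1-c1ccc(C2(N)CC2)cc1` is one of three close relatives that share a common core and differ only in a single group on a six-membered aromatic ring of carbon only. In an assay on isolated protein for inhibition of ubiquitin carboxyl-terminal hydrolase 7 (Homo sapiens), with stated times of 30 min and 2 h (a higher number here means a weaker inhibitor, a lower number a stronger inhibitor), compound 2 gives 66.1 nM. Compound 1 `Cn1nc2c(=O)n(CC3(O)CCN(Cc4ccc(-c5ccco5)cc4Cl)CC3)cnc2c1-c1ccc(CO)cc1`, which carries hydroxymethyl at that position, gives 42.5 nM, and compound 3 `Cn1nc2c(=O)n(CC3(O)CCN(Cc4ccc(-c5ccco5)cc4Cl)CC3)cnc2c1-c1ccc(C(F)(F)F)cc1`, which carries trifluoromethyl there, gives 530 nM. Compound 2 therefore stands second highest of the three numbers; the step of a 1.6-fold higher number from compound 1 to compound 2 (0.19 log units; within the scatter) lies within the scatter, while the step of an 8.0-fold higher number from compound 2 to compound 3 (0.90 log units; beyond the scatter) lies beyond it, as does the step of a 12-fold higher number from compound 1 to compound 3 (1.10 log units; beyond the scatter).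

Compound 4 `Cn1nc2c(=O)n(CC3(O)CCN(Cc4ccc(-c5ccco5)cc4Cl)CC3)cnc2c1-c1ccc(CNS(C)(=O)=O)cc1` is not yet measured. It differs from compound 2 in one place: (methanesulfonamido)methyl in place of 1-aminocyclopropyl on an aromatic carbon. Both groups that have kept the number low, hydroxymethyl and 1-aminocyclopropyl, bring 1 hydrogen-bond donor, and the entering (methanesulfonamido)methyl also brings 1 hydrogen-bond donor together with 2 hydrogen-bond acceptors, whereas trifluoromethyl, which brings none, raised the number markedly in the step from compound 2 to compound 3. On this basis compound 4 is expected to behave much like compound 1 and compound 2, with a step of a 1.1-fold lower number from compound 2 to compound 4 (0.04 log units; within the scatter) that stays within the scatter. Compound 4 is estimated at 60 nM, with a likely range from 25 nM to 150 nM.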

Compound 4, half-maximal inhibitory concentration: 65.3 nM
The estimate for compound 4 lay 1.1-fold (0.04 log units) below the measured number; low and high end bracket the measured number.
By their numbers in this assay, from the lowest: compounds 1, 4 and 2 (each within the scatter of the next); then compound 3.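

On this position, para to a large group, the ring-free (methanesulfonamido)methyl is accepted as readily as the 1-aminocyclopropyl ring in this assay, with a 1.0-fold lower number from compound 2 to compound 4 (0.01 log units; within the scatter) despite its greater number of heavy atoms and its sulfur, and with a 1.5-fold higher number from compound 1 to compound 4 (0.19 log units; within the scatter) when methanesulfonamido replaces the hydroxy of hydroxymethyl. Against trifluoromethyl the picture is different, with an 8.1-fold lower number from compound 3 to compound 4 (0.91 log units; beyond the scatter) showing that compound 3 remains the one clear outlier, while three quite different groups that each bring a hydrogen-bond donor now sit together within the scatter. Nothing available explains why these groups give such similar numbers or why trifluoromethyl stands apart.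

The compounds shown leave open whether the hydrogen-bond donor itself matters, since trifluoromethyl differs from the other groups in more than that count, and a methoxymethyl group or a methanesulfonamidomethyl group with a methyl on its nitrogen would put this more directly to the test. They also leave open how much more this position would accept, for instance a carboxylic acid or a longer chain ending in an amine.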